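Exchanging one phenyl group on compound 2

This account rests on a few compounds, and the source may have more. Where it says the series, first, only, none or still open, it means among the compounds named here.

Measured in a functional assay on MDA-MB-436 cells (Homo sapiens) for antiproliferative activity, read by MTT assay, with a stated time of 24 h; on this read-out higher numbers stand for weaker inhibition and lower numbers for stronger inhibition:
- compound 1 `COc1ccccc1C(=O)NC(CC(=O)O)c1ccccc1`: > 100000 nM (a limit, not a number)
- compound 2 `O=C(O)CC(NC(=O)c1ccc(Cl)cc1Cl)c1ccccc1F`: > 100000 nM (a limit, not a number)
- compound 3 `O=C(O)CC(NS(=O)(=O)c1cc(F)cc(F)c1)c1ccccc1F`: 89300 nM

The results so far are dominated by the limit of > 100000 nM in this assay, at which 2 of the 3 values shown sit. Compound 2 is one of the two compounds at that limit, so its result gives no exact number to start from.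

The next compound to be tested is compound 4 `O=C(O)CC(NC(=O)c1ccc(Cl)cc1Cl)c1ccc(Cl)cc1Cl`, which keeps the rest of compound 2 and changes one group: 2,4-dichlorophenyl in place of 2-fluorophenyl on a saturated chain carbon bound to an amide-type nitrogen and a saturated chain carbon. In words, it has 2,4-dichlorophenyl in place of 2-fluorophenyl on a saturated chain carbon bound to an amide-type nitrogen and a saturated chain carbon.

Among the compounds with values here, no pair of measured compounds shows what a change of this kind does, so the expectation rests on the values alone. Within the data shown here, the only exact number comes from compound 3, at 89300 nM, and that gives little reason to expect strong inhibition from this small set. The expected change is a number no higher from compound 2 to compound 4 (the limit leaves the size open), which means no step beyond the usual scatter and no firm direction. It is also quite possible that the result will again be only a limit. For compound 4 the estimated value is 100000 nM, with an expected range from 40000 nM to 250000 nM.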

Compound 4, half-maximal inhibitory concentration: 57300 nM
Estimate against measurement, compound 4: 1.7-fold (0.24 log units) above; low and high end bracket the measured number.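

Compound 2 gives > 100000 nM in this assay, which is a limit and not a number. With 2,4-dichlorophenyl on the saturated chain carbon bound to an amide-type nitrogen and a saturated chain carbon, compound 4 gives 57300 nM, so this change at this position yields an exact value where compound 2 gave none, although inhibition remains weak on this read-out. The step is an at least 1.7-fold lower number from compound 2 to compound 4 (0.24 log units; that floor lies within the scatter), and its true size cannot be read because compound 2 supplies only a limit: the limit of > 100000 nM in this assay, at which 2 of the 4 values shown sit.

The compounds shown leave open whether both chlorines of the 2,4-dichlorophenyl group are required for this result, or whether a phenyl group carrying a single chlorine on that same carbon would give a similar value. On these data alone, they also leave open what would happen if an amine or a longer chain stood in place of the carboxylic acid that all four compounds share, so the part played by that acid in this assay remains unknown.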